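Cytotoxicity Unchanged by Substituents on the Ring Nitrogen

This account rests on a few compounds, and the source may have more. Where it says the series, first, only, none or still open, it means among the compounds named here.

Measured compounds:
- compound 1 `Cc1nc(N)nc(N[C@@H]2C[C@H](CO)[C@@H](O)[C@H]2O)c1-c1nc2cnccc2s1` — 25000 nM
- compound 2 `Cc1nc(NC2CC2)nc(N[C@@H]2C[C@H](CO)[C@@H](O)[C@H]2O)c1-c1nc2cnccc2s1` — 25000 nM
- compound 3 `Cc1nc(NCc2ccccc2)nc(N[C@@H]2C[C@H](CO)[C@@H](O)[C@H]2O)c1-c1nc2cnccc2s1` — 25000 nM

All three compounds were tested in an ADME assay on cells (Homo sapiens) for cytotoxicity, read by polymerase chain reaction, with a stated time of 3 days; on this read-out lower numbers stand for higher toxicity in this test and higher numbers for lower toxicity in this test. Compound 1 stands level with compound 2 and compound 3 at the digits shown, and the gaps between the three are all within the scatter of the test. For the measured compounds named here, the steps that bear on the present question are no change at the digits printed from compound 1 to compound 2 (within the scatter), no change at the digits printed from compound 1 to compound 3 (within the scatter) and no change at the digits printed from compound 2 to compound 3 (within the scatter): replacing the hydrogen on the nitrogen of the aromatic ring with a small ring or a benzyl group left the read-out in this assay where it was.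

The untested compound 4 `Cc1nc(NCc2ccc(OC(F)(F)F)cc2)nc(N[C@@H]2C[C@H](CO)[C@@H](O)[C@H]2O)c1-c1nc2cnccc2s1` differs from compound 1 by 4-(trifluoromethoxy)benzyl in place of hydrogen on a nitrogen on an aromatic ring. This is again a substituent on the same nitrogen, larger than the benzyl of compound 3 but of the same kind. Because the steps of no change at the digits printed from compound 1 to compound 3 (within the scatter) and no change at the digits printed from compound 2 to compound 3 (within the scatter) showed no change beyond the scatter, no shift beyond the scatter is expected for compound 4 either, which is what no change at the digits printed from compound 1 to compound 4 (within the scatter) expresses. Compound 4 is therefore estimated at 25000 nM, with a range of 12000 nM to 50000 nM.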

Compound 4, half-maximal cytotoxic concentration: 25000 nM
Beside the measured number, compound 4's estimate shows no gap at the digits printed; the range from low to high includes it.
By their numbers in this assay, from the lowest: compounds 1, 2, 3 and 4 (each within the scatter of the next).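

In this assay, the nitrogen on the aromatic ring now also tolerates 4-(trifluoromethoxy)benzyl, a group of 12 heavy atoms, with steps of no change at the digits printed from compound 1 to compound 4 (within the scatter) and no change at the digits printed from compound 2 to compound 4 (within the scatter). For the compounds shown here, compound 4 also adds the first change on the benzyl ring itself, trifluoromethoxy in place of hydrogen on an aromatic carbon, and that step is no change at the digits printed from compound 3 to compound 4 (within the scatter). No supporting data are available to explain why these values are level.

The compounds shown carry only hydrogen, cyclopropyl, benzyl and 4-(trifluoromethoxy)benzyl on this nitrogen, so a chain ending in an amine or a carboxylic acid remains an open case. From the compounds shown here alone, the read-out for changes elsewhere on the shared core also remains open.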